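Trimming the Amine Side Chain of Compound 3

The source may report more compounds than this note shows. Statements on the series, on what has been measured and on what is new or still open speak of the compounds shown alone.

Among the three numbers gathered so far in an assay on cells for displacement of a labelled ligand from corticotropin-releasing factor receptor 1 (Homo sapiens), with a stated time of 100 min (on this read-out higher numbers stand for weaker inhibition and lower numbers for stronger inhibition), compound 3 `Cc1cc(C)c(-n2c(Cl)cn3c(CN(CCC(F)(F)F)Cc4ccccc4)c(C(F)(F)F)nc23)c(C)c1` stands second highest, giving 43 nM. Its nearest neighbour is compound 1 `Cc1cc(C)c(-n2c(Cl)cn3c(CN(CCC(F)(F)F)CC4CC4)c(C(F)(F)F)nc23)c(C)c1`, which in this assay gives 16 nM, so that the step of a 2.7-fold higher number from compound 1 to compound 3 (0.43 log units; beyond the scatter) is modest. Furthest away is compound 2 `CCCCN(C)Cc1c(C(F)(F)F)nc2n(-c3c(C)cc(C)cc3C)c(Cl)cn12`, which in this assay gives 310 nM, and the step of a 19-fold higher number from compound 1 to compound 2 (1.29 log units; beyond the scatter) is large.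

Compound 4 `Cc1cc(C)c(-n2c(Cl)cn3c(CN(C)Cc4ccccc4)c(C(F)(F)F)nc23)c(C)c1` has not yet been measured. It differs from compound 3 by hydrogen in place of 2,2,2-trifluoroethyl on a saturated chain carbon bound to an amine nitrogen. Among the measured compounds shown here, no measured step isolates exactly this change. The step of a 19-fold higher number from compound 1 to compound 2 (1.29 log units; beyond the scatter) bears on it most closely, since there butyl(methyl)amino replaced (cyclopropylmethyl)(3,3,3-trifluoropropyl)amino, a change that contains the removal of the 3,3,3-trifluoropropyl in favour of methyl alongside a second alteration, and that step was large. The step of a 2.7-fold higher number from compound 1 to compound 3 (0.43 log units; beyond the scatter) shows that the other group on the same amine nitrogen also shifts the number. Taken together, these steps point to a loss of inhibition for compound 4. Only part of that combined change is made here, and a smaller loss than in that combined step is anticipated.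

Compound 4 is therefore expected to give about 200 nM in this assay, with a likely range from 60 nM to 700 nM. The expected step of a 4.7-fold higher number from compound 3 to compound 4 (0.67 log units; beyond the scatter) is toward weaker inhibition and beyond the scatter.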

Compound 4, inhibition constant: 160 nM
Beside the measured number, compound 4's estimate is 1.3-fold (0.10 log units) above it; measured number inside the range.
By their numbers in this assay, from the lowest: compound 1; then compound 3; then compounds 4 and 2 (each within the scatter of the next).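

With the benzyl group held constant in this assay, the step of a 3.7-fold higher number from compound 3 to compound 4 (0.57 log units; beyond the scatter) isolates 3,3,3-trifluoropropyl to methyl on the amine nitrogen, a single change that the earlier combined step could not separate, and it lies beyond the scatter in the direction of weaker inhibition. Once methyl sits on that nitrogen, replacing propyl with phenyl on the saturated chain carbon bound to it gives a 1.9-fold lower number from compound 2 to compound 4 (0.29 log units; within the scatter) and so makes no difference that can be read, while the full exchange of both amine substituents gives a 10-fold higher number from compound 1 to compound 4 (1.00 log units; beyond the scatter) and shows how far the two changes together carry the number. Nothing available here explains why these changes have these effects.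

The compounds shown leave open whether the fluorine atoms or the length of the chain carry the step to methyl, and a plain propyl group on that nitrogen would separate the two. They also leave open how the number would respond to cyclopropylmethyl paired with methyl on the same amine nitrogen.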